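Trimming a Side Chain on a Shared Core

This account rests on a few compounds, and the source may have more. Where it says the series, first, only, none or still open, it means among the compounds named here.

This piece follows one change made to a shared core. Compound 1, `O=C(NCc1ccc(F)cc1)c1nc(NCCO)c2cccnc2c1O`, has no result in a functional assay on HCT-116 cells (Homo sapiens) for cytotoxicity, read by MTT assay, with a stated time of 72 h; on this read-out lower numbers stand for stronger inhibition and higher numbers for weaker inhibition: its entry reads "not determined" (no result reported). Compound 2, `C[C@@H](Nc1c(C(=O)NCc2ccc(F)cc2)nc(Br)c2cccnc12)c1ccccc1`, was tested and gave > 20000 nM, which is a limit of the assay rather than a measured number. On the numbers shown, compound 2 thus stands at the limit of > 20000 nM in this assay, at which 1 of the 2 values shown sits, with the other entry giving no number at all. Going by the values given here, no step between two measured compounds can be drawn from these two entries.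

Compound 3, `CNc1c(C(=O)NCc2ccc(F)cc2)nc(Br)c2cccnc12`, differs from compound 2 in one place: methyl in place of 1-phenylethyl on a nitrogen on an aromatic ring. With compound 2 sitting at a limit, the size of a step cannot be read from a pair of numbers. The expectation is that the step that the limit leaves unreadable from compound 2 to compound 3 amounts to none beyond the scatter, with compound 3 most likely also reported only as a limit. Compound 3 is estimated at 25000 nM, with a range from 8000 nM to 60000 nM.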

Compound 3, half-maximal inhibitory concentration: > 20000 nM
Compound 3: only a limit was reported (the forecaster's own chance of this, stated with the estimate: 75%); the middle value is on the limit's open side.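

Going by these compounds alone, compound 2 and compound 3 are both reported only as limits in this assay, so no step of readable size can be drawn for methyl in place of 1-phenylethyl. The compounds shown leave open whether any compound on this shared core gives a measured number in this assay, and what this change would do to such a number.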